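A Phenyl Ketone Replaces the Allyl Amide

The source may hold more compounds than are shown below. What is called first, only, known or untested is meant among the compounds shown, and "the series" means these compounds.

Three compounds share a long branched unsaturated chain ending in a carbonyl group, and they differ only in what sits on that carbonyl carbon. Compound 1 `CCC(C)OC(=O)/C=C(C)/C=C/CC(C)CCCC(C)C` carries a sec-butoxy group there, and in a physicochemical assay for lipophilicity (on this read-out lower numbers stand for lower lipophilicity and higher numbers for higher lipophilicity), compound 1 gives 7.69. Compound 2 `CCNC(=O)/C=C(C)/C=C/CC(C)CCCC(C)C` carries an ethylamino group, and in this assay compound 2 gives 5.24. Compound 3 `C=CCNC(=O)/C=C(C)/C=C/CC(C)CCCC(C)C` carries an allylamino group, and in this assay compound 3 gives 5.23, the lowest of the three numbers, with compound 2 within the scatter of it and compound 1 far higher.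

The measured steps show one large movement: a number 2.45 log units lower from compound 1 to compound 2 (beyond the scatter) and a number 2.46 log units lower from compound 1 to compound 3 (beyond the scatter), while a number 0.01 log units lower from compound 2 to compound 3 (within the scatter) changes nothing beyond the scatter.

Compound 4 `CC(/C=C/CC(C)CCCC(C)C)=C\C(=O)c1ccccc1` is the next step from compound 3: phenyl in place of allylamino on a carbonyl carbon. The amide-type nitrogen with its one hydrogen-bond donor is gone, and a phenyl ring stands on the carbonyl carbon instead. The two large measured steps ran in the opposite direction, from an oxygen-linked group to a nitrogen-linked one, so the return from a nitrogen-linked group to a carbon-linked ring is expected to move this assay upward by a comparable amount, a number 2.17 log units higher from compound 3 to compound 4 (beyond the scatter). Compound 4 is therefore estimated at 7.4, within a range from 6.8 to 8.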

Compound 4, partition coefficient: 7.26
Beside the measured number, compound 4's estimate is 0.14 log units above it, within the range that was stated.
By their numbers in this assay, from the lowest: compounds 3 and 2 (each within the scatter of the next); then compound 4; then compound 1.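

On this carbonyl carbon, a phenyl ring separates clearly from both nitrogen-linked groups in this assay: a number 2.03 log units higher from compound 3 to compound 4 (beyond the scatter), and a number 2.02 log units higher from compound 2 to compound 4 (beyond the scatter), so the large gap seen earlier is not tied to the oxygen-linked sec-butoxy group alone. Phenyl does not fully match sec-butoxy, however: a number 0.43 log units lower from compound 1 to compound 4 (beyond the scatter), a modest step, which places compound 4 between the two amides and compound 1. No measurement in hand accounts for the direction or size of these shifts.

The change from compound 3 to compound 4 removes the nitrogen with its hydrogen-bond donor and adds an aromatic ring in a single step, so the compounds shown cannot divide the rise between those two parts. An anilino group would keep both the ring and the nitrogen on the carbonyl carbon, while a plain methyl group would have neither, and these are the kinds of groups that could separate the two parts.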